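The compounds below may be only part of what the source reports. "The series", "measured", "known", "first", "only" and "open" are said of these compounds alone.

Working notes on the series

For the measured compounds named here, compound 1 `Nc1cc(N)c2nc(-c3ccccc3)c(Oc3ccc(Cl)c(Cl)c3)nc2c1` is one of two compounds measured in a functional assay on SW-620 cells (Homo sapiens) for inhibition, read by sulforhodamine B assay, with a stated time of 48 h (on this read-out lower numbers stand for stronger inhibition of growth and higher numbers for weaker inhibition of growth), where compound 1 gives 9770 nM. The second measured compound, compound 2 `CCOC(=O)[C@H](CCC(=O)O)NC(=O)c1ccc(Sc2nc3cc(N)cc(N)c3nc2-c2ccccc2)cc1`, gives in this assay 11700 nM; the gap between the two values lies within the usual scatter of the read-out, so neither number can be placed above or below the other with confidence. Both compounds share a core that carries a phenyl group and an aryl-linked substituent on the same six-membered aromatic ring with two nitrogen atoms.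

Compound 3 `Nc1cc(N)c2nc(-c3ccccc3)c(Sc3ccc(F)cc3)nc2c1` has not been measured. Relative to compound 1 it carries the change ((4-fluorophenyl)sulfanyl in place of 3,4-dichlorophenoxy on an aromatic carbon). Going by the values given here, nothing measured so far speaks to how such a swap moves the read-out, and the two values on record lie close together despite unrelated substituents at this position. For compound 3 the expected step of a 1.0-fold higher number from compound 1 to compound 3 (0.01 log units; within the scatter) is therefore taken as none beyond the scatter, and the estimated value in this assay is 10000 nM, with a range from 3000 nM to 33000 nM.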

Compound 3, concentration for 50% growth inhibition: 22900 nM
Beside the measured number, compound 3's estimate is 2.3-fold (0.36 log units) below it; measured number inside the range.
By their numbers in this assay, from the lowest: compounds 1, 2 and 3 (each within the scatter of the next, the first and the last beyond it).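

For the compounds shown here, the change from 3,4-dichlorophenoxy to (4-fluorophenyl)sulfanyl gives the first readable step at this position in this assay (a 2.3-fold higher number from compound 1 to compound 3 (0.37 log units; beyond the scatter)), a modest move towards weaker inhibition of growth. This position on the shared core therefore responds to the group it carries, at least for this pair. The change alters the linking atom and the ring substituents together, so the share of each in the step cannot be read, and nothing on record accounts for it.

The compounds shown leave open whether 4-fluorophenoxy or (3,4-dichlorophenyl)sulfanyl would separate the contribution of the linking atom from that of the chlorine and fluorine atoms. They also leave open how an amine or a longer alkyl chain on this aromatic carbon would compare with the aryl-linked groups.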